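Anilino to Ethylamino on a Shared Core, Cytotoxicity Unchanged

The source may report more compounds than this note shows. Statements on the series, on what has been measured and on what is new or still open speak of the compounds shown alone.

Compound 1 `Cc1nc(NC(C)C)c2cnn(-c3ccccc3)c2n1` in a functional assay on G-361 cells (Homo sapiens) for cytotoxicity, read by sulforhodamine B assay (on this read-out lower numbers stand for higher toxicity in this test and higher numbers for lower toxicity in this test), gives > 100000 nM, which is a limit of the assay and not a number.
Compound 2 `Cc1nc(NCc2ccco2)c2cnn(-c3ccccc3)c2n1` in this assay gives > 100000 nM, again a limit of the assay.
Compound 3 `Cc1nc(Nc2ccccc2)c2cnn(-c3ccccc3)c2n1` in this assay gives > 100000 nM, once more a limit of the assay.

Compound 3 therefore stands nowhere in particular among the numbers shown: all three measured compounds sit at the limit of > 100000 nM in this assay, at which 3 of the 3 values shown sit, and none of them is separated from another by a readable step. The step that the two limits leave unreadable from compound 1 to compound 3, the step that the two limits leave unreadable from compound 2 to compound 3 and the step that the two limits leave unreadable from compound 1 to compound 2 are all unreadable for that reason.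

Compound 4 `CCNc1nc(C)nc2c1cnn2-c1ccccc1` differs from compound 3 by ethyl in place of phenyl on a nitrogen on an aromatic ring, the change that, cut one bond further out, reads anilino to ethylamino. Among the compounds with values here, the steps that bear on this change are those that also swap the group on that nitrogen, from isopropyl or from (furan-2-yl)methyl to phenyl, and both of them, a step that the two limits leave unreadable from compound 1 to compound 3 and a step that the two limits leave unreadable from compound 2 to compound 3, left no size to read. Compound 4 is therefore expected to show the step that the limit leaves unreadable from compound 3 to compound 4, that is, nothing that the limit could resolve. Compound 4 is estimated at 150000 nM, between 50000 nM and 400000 nM, most likely reported only as a limit in this assay.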

Compound 4, concentration lethal to 50% of the cells: > 100000 nM
Compound 4: a limit, no number; the forecaster's own chance of this, stated with the estimate: 85%; the middle value lies beyond the limit too.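

Compound 4 gives only a limit in this assay, as do compound 1, compound 2 and compound 3, so no step among these compounds can be read: the limit of > 100000 nM in this assay, at which 4 of the 4 values shown sit.

The compounds shown leave open how toxic any of them actually is, and whether any group on that nitrogen changes the read-out at all.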